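Swapping pentafluoroethyl for thiophene on the shared core

The source may hold more compounds than are shown below. What is called first, only, known or untested is meant among the compounds shown, and "the series" means these compounds.

Measured in a functional assay on Jurkat cells (Homo sapiens) for inhibition; a lower number here means a stronger inhibitor, a higher number a weaker inhibitor:
- compound 1 `CCOC(=O)c1cnc(NN2C(=O)C=C(c3ccccc3)C2=O)nc1C(F)(F)F`: 3700 nM
- compound 2 `CCOC(=O)c1cnc(N(Cc2ccccc2)N2C(=O)C=C(C)C2=O)nc1C(F)(F)F`: 450 nM
- compound 3 `CCOC(=O)c1cnc(NN2C(=O)C=C(C)C2=O)nc1C(F)(F)C(F)(F)F`: 200 nM

Of these three, compound 3 has the lowest number and is the strongest inhibitor, ahead of compound 2 at 450 nM and compound 1 at 3700 nM. The next compound, compound 4 `CCOC(=O)c1cnc(NN2C(=O)C=C(C)C2=O)nc1-c1ccsc1`, keeps the rest of compound 3 but carries thiophen-3-yl in place of 1,1,2,2,2-pentafluoroethyl on an aromatic carbon, next to the ring nitrogen and ortho to an ethoxycarbonyl group (thiophen-3-yl in place of 1,1,2,2,2-pentafluoroethyl on an aromatic carbon). Among the measured compounds shown here, no measured compound carries a ring at this place, and no pair of measured compounds differs only there, so the data offer no direct guide to the size of this step. In this assay, a moderate move toward a higher number is expected, meaning a somewhat weaker inhibitor, though with wide uncertainty. The estimated change is a 3.0-fold higher number from compound 3 to compound 4 (0.48 log units; beyond the scatter). The value expected for compound 4 is 600 nM, with an estimated range of 150 nM to 2500 nM.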

Compound 4, half-maximal inhibitory concentration: 200 nM
Compound 4: middle estimate off by 3.0-fold (0.48 log units), on the high side; the measured number falls inside the stated range.
By their numbers in this assay, from the lowest: compounds 3 and 4 (each within the scatter of the next); then compound 2; then compound 1.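

In this assay, thiophen-3-yl in place of 1,1,2,2,2-pentafluoroethyl gives no change at the digits printed from compound 3 to compound 4 (within the scatter). Among the compounds shown here, this is the first direct reading at this place, and it shows that, in this one pair, a five-membered aromatic ring with no fluorine can stand on this aromatic carbon, next to the ring nitrogen and ortho to the ethoxycarbonyl group, with the number unmoved, although the earlier compounds carried only fluorinated chains here. Nothing in the data accounts for this result.

As far as these compounds go, whether a phenyl ring, a thiophen-2-yl group or a furan ring would give a similar number remains open. So does the effect of a plain ethyl chain or an amine at this place, and a single pair cannot say whether the result holds on other versions of the shared core.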